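The compounds below may be only part of what the source reports. "The series", "measured", "known", "first", "only" and "open" are said of these compounds alone.

In an ADME assay on L1210/0 cells (Mus musculus) for cytotoxicity, with a stated time of 48 h (on this read-out higher numbers stand for weaker inhibition and lower numbers for stronger inhibition), compound 1 `CC1(C)[C@H](CCO)C[C@@H]1n1cnc2c(Cl)nc(N)nc21` gives 105000 nM. Compound 2 `[N-]=[N+]=NCc1cn([C@H]2C[C@H](O)[C@@H](CO)O2)c(=O)[nH]c1=O` gives 124000 nM, and these two numbers lie within the usual scatter of each other, so compound 2 stands level with compound 1. Compound 3 `C[S+]([O-])c1cn([C@H]2C[C@H](O)[C@@H](CO)O2)c(=O)[nH]c1=O` differs from compound 2 in one place: a group of 3 heavy atoms (1 carbon, 1 oxygen, 1 sulfur; no ring) in place of a group of 4 heavy atoms (1 carbon, 3 nitrogen; no ring), on an aromatic carbon. Within the data shown here, no measured step bears on this change, so the prediction rests on little. The estimated 1.2-fold higher number from compound 2 to compound 3 (0.08 log units; within the scatter) is expected to stay within the scatter, with no clear direction. Compound 3 is expected at an estimated 150000 nM, within a range from 40000 nM to 500000 nM.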

Compound 3, half-maximal inhibitory concentration: > 200000 nM
Compound 3: a limit, no number (the forecaster's own chance of this, stated with the estimate: 35%); middle value at least 1.3-fold (0.12 log units) away from the limit.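

At this aromatic carbon, replacing azidomethyl with the sulfur-containing group of compound 3 brings no sign of stronger inhibition in this assay. From the compounds shown here alone, compound 3 gives a limit and not a number: the limit of > 200000 nM in this assay, at which 1 of the 3 values shown sits. The change reads as an at least 1.6-fold higher number from compound 2 to compound 3 (0.20 log units; that floor lies within the scatter), so the step has a floor only, and its true size stays unknown.

The compounds shown leave open how an amine or a carboxylic acid at this carbon would read. They also leave open whether any group here would give a clearly lower number than azidomethyl.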